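Thiourea-to-urea change on the ring nitrogen, second pair

A few compounds are considered here, and "the series" means these few. Any claim that something is new, unique, unknown or untested is made for them only; others in the source may bear on it.

Measured compounds:
compound 1 `NC(=O)c1c(NC(=O)c2ccccc2F)sc2c1CCN(C(=S)Nc1ccccc1Cl)C2`: 19400 nM
compound 2 `NC(=O)c1c(NC(=O)c2ccccc2F)sc2c1CCN(C(=O)Nc1ccccc1Cl)C2`: > 50000 nM
compound 3 `NC(=O)c1c(NC(=O)c2ccc(C(F)(F)F)cc2)sc2c1CCN(C(=S)Nc1ccccc1Cl)C2`: 44000 nM

In a functional assay on HeLa cells (Homo sapiens) for antiproliferative activity, with a stated time of 24 h (a higher number here means a weaker inhibitor, a lower number a stronger inhibitor), compound 1 gives 19400 nM. In this assay compound 2 reaches only a limit, > 50000 nM. Compound 3 gives 44000 nM in this assay. The change a group of 10 heavy atoms (7 carbon, 1 nitrogen, 1 oxygen, 1 chlorine; one six-membered aromatic ring of carbon only) in place of a group of 10 heavy atoms (7 carbon, 1 nitrogen, 1 sulfur, 1 chlorine; one six-membered aromatic ring of carbon only), on an amine nitrogen in a ring produced an at least 2.5-fold higher number from compound 1 to compound 2 (0.41 log units; beyond the scatter), a step whose size is known only as a lower bound because compound 2 sits at the limit of > 50000 nM in this assay, at which 1 of the 3 values shown sits. The two cores differ by 4-(trifluoromethyl)phenyl in place of 2-fluorophenyl on a carbonyl carbon, which gave a 2.3-fold higher number from compound 1 to compound 3 (0.36 log units; beyond the scatter).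

Compound 4 `NC(=O)c1c(NC(=O)c2ccc(C(F)(F)F)cc2)sc2c1CCN(C(=O)Nc1ccccc1Cl)C2` is not yet measured. It differs from compound 3 by a group of 10 heavy atoms (7 carbon, 1 nitrogen, 1 oxygen, 1 chlorine; one six-membered aromatic ring of carbon only) in place of a group of 10 heavy atoms (7 carbon, 1 nitrogen, 1 sulfur, 1 chlorine; one six-membered aromatic ring of carbon only), on an amine nitrogen in a ring, the same change as from compound 1 to compound 2. For compound 4 in this assay a step of a 2.5-fold higher number from compound 3 to compound 4 (0.40 log units; beyond the scatter) is expected. This expectation rests on the value of compound 3, 44000 nM, with an at least 2.5-fold higher number from compound 1 to compound 2 (0.41 log units; beyond the scatter) applied to it. Compound 4 is therefore estimated at 110000 nM, most likely reported as a limit.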

Compound 4, half-maximal inhibitory concentration: > 50000 nM
Compound 4 gave a limit, no number; the forecaster's own chance of this, stated with the estimate: 85%; the middle value is on the limit's open side.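

In this assay compound 4 reaches only a limit, > 50000 nM. Placing (2-chlorophenyl)carbamoyl on the ring nitrogen of the second core gives an at least 1.1-fold higher number from compound 3 to compound 4 (0.05 log units; that floor lies within the scatter), so this pair does not go against the direction seen on the first core, but it does not confirm that direction either. Carry-over of the change is therefore compatible with the data but not shown, and its size on the second core remains unknown: the same change on two cores in this assay, an at least 2.5-fold higher number (0.41 log units; beyond the scatter) from compound 1 to compound 2 and an at least 1.1-fold higher number (0.05 log units; that floor lies within the scatter) from compound 3 to compound 4; the limit leaves it open whether they differ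

On these data alone, the step from compound 2 to compound 4 cannot be read, so the effect of 4-(trifluoromethyl)phenyl in place of 2-fluorophenyl on the urea core stays open: the limit of > 50000 nM in this assay, at which 2 of the 4 values shown sit. Also open is how a guanidine or a sulfonamide on the ring nitrogen would compare with the thiourea of compound 1.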